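Aryl Hydrazone Swap on a Shared Urea Core

This account rests on a few compounds, and the source may have more. Where it says the series, first, only, none or still open, it means among the compounds named here.

Compound 1 `CN(C)CCn1cnnc1-c1cc(Oc2ccc(NC(=O)N/N=C/c3c[nH]c4ccccc34)cc2F)ccn1`: 820 nM
Compound 2 `CN(C)CCn1cnnc1-c1cc(Oc2ccc(NC(=O)N/N=C/c3cc(Br)c(O)c(Br)c3)cc2F)ccn1`: > 100000 nM

In a functional assay on A549 cells (Homo sapiens) for cytotoxicity, read by MTT assay, with a stated time of 72 h (a lower number here means a stronger inhibitor, a higher number a weaker inhibitor), compound 1 gives 820 nM. For compound 2 this assay reports only a limit, > 100000 nM. Among the measured compounds shown here, the single change between the two gives an at least 120-fold higher number from compound 1 to compound 2 (2.08 log units; beyond the scatter), so compound 2 sits at the limit of > 100000 nM in this assay, at which 1 of the 2 values shown sits, and its true number is not known beyond that. Compound 3 `CN(C)CCn1cnnc1-c1cc(Oc2ccc(NC(=O)N/N=C/c3ccc(Cl)cc3)cc2F)ccn1` differs from compound 2 by 4-chlorophenyl in place of 3,5-dibromo-4-hydroxyphenyl on a carbon with a double bond to nitrogen. For the measured compounds named here, no measured step covers this exact change; the one step available shows only that the group on that carbon can shift the number greatly, with the indol-3-yl of compound 1 far stronger than the dibromohydroxyphenyl of compound 2. A number back below the limit is therefore expected, though with wide uncertainty. With that uncertainty, the expected step for compound 3 is an at least 16-fold lower number from compound 2 to compound 3 (1.22 log units; beyond the scatter). The estimate for compound 3 in this assay is 6000 nM, within 800 nM to 100000 nM.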

Compound 3, half-maximal inhibitory concentration: 780 nM
For compound 3 the middle estimate is 7.7-fold (0.89 log units) above the measured one; the measured number lies below the stated range.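

In this assay, 4-chlorophenyl in place of 3,5-dibromo-4-hydroxyphenyl on a carbon with a double bond to nitrogen gives an at least 120-fold lower number from compound 2 to compound 3 (2.10 log units; beyond the scatter). The value of compound 2 is only a limit: the limit of > 100000 nM in this assay, at which 1 of the 3 values shown sits. Replacing 1H-indol-3-yl with 4-chlorophenyl at the same place gives a 1.1-fold lower number from compound 1 to compound 3 (0.02 log units; within the scatter), which lies within the scatter, so this position accepts both a fused ring with a hydrogen-bond donor and a single chlorinated ring, and among the three compounds only compound 2 goes against this.

Compound 2 carries both bromine atoms and the hydroxyl, so the compounds shown do not tell which of these goes with its limit. On these data alone, a 4-hydroxyphenyl, a 3,5-dibromophenyl or an aliphatic amine on that carbon remains open.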